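A few compounds are considered here, and "the series" means these few. Any claim that something is new, unique, unknown or untested is made for them only; others in the source may bear on it.

Two measured compounds set the scene. Compound 1 `Cc1ccc(C(=O)NC(=S)NNc2ncnc3ccccc23)cc1` and compound 2 `COc1cc2ncnc(NNC(=S)NC(=O)c3ccccc3)c2cc1OC` were both tested in a functional assay on KB cells (Homo sapiens) for cytotoxicity, read by MTT assay, with a stated time of 72 h; a lower number here means a stronger inhibitor, a higher number a weaker inhibitor. In this assay compound 1 gives 10100 nM, while compound 2 gives 3770 nM. Compound 1 therefore has the higher of the two numbers, and its gap to compound 2 lies beyond the usual scatter of the measurement, so compound 1 is the weaker inhibitor of the pair. The unmeasured compound 3 `Cc1ccccc1C(=O)NC(=S)NNc1ncnc2ccccc12` keeps the core of compound 1 and is built from the same atoms joined differently: 2-methylphenyl in place of 4-methylphenyl on a carbonyl carbon. Within the data shown here, no pair of measured compounds that differ only in this way is available, so there is no measured step to lean on, and compound 2 differs from compound 1 in more than one place, giving no guidance on this change. The step expected for this change, a 1.0-fold lower number from compound 1 to compound 3 (0.00 log units; within the scatter), is taken to be no change beyond the scatter in either direction. For compound 3 in this assay the estimated value is 10000 nM, with an expected range from 4000 nM to 25000 nM.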

Compound 3, half-maximal inhibitory concentration: 2770 nM
Beside the measured number, compound 3's estimate is 3.6-fold (0.56 log units) above it; measured number below the stated range.
By their numbers in this assay, from the lowest: compounds 3 and 2 (each within the scatter of the next); then compound 1.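

Among these compounds, replacing 4-methylphenyl with 2-methylphenyl on a carbonyl carbon whose other neighbour is an amide-type nitrogen gives the first measured step at this position, and in this assay it amounts to a 3.6-fold lower number from compound 1 to compound 3 (0.56 log units; beyond the scatter), a modest change that still lies beyond the scatter. The two groups match in every count computed for them, with the same heavy atoms, the same aromatic ring and no net charge, yet they are not interchangeable on the core of compound 1, so the way the same atoms are joined in this group is enough on its own to shift the number. Nothing measured for these compounds speaks to the reason for this shift.

The compounds shown leave open whether 2-methylphenyl would give a step of similar size on the core of compound 2, since that compound carries neither of the two methylphenyl groups. They also leave open whether the methyl of 2-methylphenyl is itself what matters on this carbonyl carbon, or whether a methoxy group or a chlorine atom in its place would give a similar number.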